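Trading 4-(trifluoromethyl)phenyl for 3-nitrophenyl in compound 2

This account rests on a few compounds, and the source may have more. Where it says the series, first, only, none or still open, it means among the compounds named here.

- Compound 1 `O=C(CCCCCCc1nc(-c2cccc([N+](=O)[O-])c2)no1)NO` gives 16100 nM
- Compound 2 `Nc1ccccc1NC(=O)CCCCCCc1nc(-c2ccc(C(F)(F)F)cc2)no1` gives 29800 nM

In a functional assay on NCI-H661 cells (Homo sapiens) for antiproliferative activity, read by MTT assay, with a stated time of 72 h (on this read-out higher numbers stand for weaker inhibition and lower numbers for stronger inhibition), compound 2 stands within the usual scatter of compound 1, so these two numbers cannot be told apart. Compound 3 `Nc1ccccc1NC(=O)CCCCCCc1nc(-c2cccc([N+](=O)[O-])c2)no1` has 3-nitrophenyl in place of 4-(trifluoromethyl)phenyl on an aromatic carbon. Within the data shown here, no measured pair shows this change directly. Compound 1 also carries 3-nitrophenyl and gives 16100 nM, close to compound 2 at 29800 nM. The expected step of a 1.2-fold lower number from compound 2 to compound 3 (0.08 log units; within the scatter) in this assay therefore stays within the scatter. Compound 3 is estimated at 25000 nM, with an expected range of 10000 nM to 60000 nM.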

Compound 3, half-maximal inhibitory concentration: 7290 nM
Compound 3: the middle estimate sits 3.4-fold (0.54 log units) above what was measured, outside the stated range (below it).
By their numbers in this assay, from the lowest: compound 3; then compounds 1 and 2 (each within the scatter of the next).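

In this assay, 3-nitrophenyl in place of 4-(trifluoromethyl)phenyl on this aromatic carbon gives a 4.1-fold lower number from compound 2 to compound 3 (0.61 log units; beyond the scatter) and shows that the group here can move the number beyond the scatter. The earlier pair, which differs in two places, could not show this. With 3-nitrophenyl held fixed, 2-aminophenyl in place of hydroxy on the amide-type nitrogen gives a 2.2-fold lower number from compound 1 to compound 3 (0.34 log units; beyond the scatter) and shows that the group there counts too.

From the compounds shown here alone, how a plain phenyl or a carboxylic acid would read at this position stays open. Nothing measured here explains either step.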